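A nitrogen-linked triazole replaces an oxadiazole on the aryl urea

The source may report more compounds than this note shows. Statements on the series, on what has been measured and on what is new or still open speak of the compounds shown alone.

The study describes ureas built on a shared core, each carrying a cycloheptyl group and a trimethylphenyl group. In a functional assay on a cell-free system (plasma) with sterol O-acyltransferase, Soat (Rattus norvegicus) as the target (on this read-out higher numbers stand for an effect only at larger amounts of compound and lower numbers for an effect already at smaller amounts), compound 1 `Cc1cc(C)c(NC(=O)N(Cc2c[nH]c(-c3ccccc3)n2)C2CCCCCC2)c(C)c1` gives only a limit, > 1 mg/kg. Compound 2 `Cc1cc(C)c(NC(=O)N(Cc2ccc(-c3nnc(C)o3)cc2)C2CCCCCC2)c(C)c1` likewise gives only a limit, > 0.32 mg/kg, so that in this assay compound 2 stands without a fixed number; the limits appear as the limit of > 0.32 mg/kg in this assay, at which 1 of the 3 values shown sits, and (the limit of > 1 mg/kg in this assay, at which 1 of the 3 values shown sits). Compound 3 `Cc1cc(C)c(NC(=O)N(Cc2cccc(-n3cccc3)c2)C2CCCCCC2)c(C)c1` gives a measured value of 0.17 mg/kg in this assay. Compound 4 `Cc1cc(C)c(NC(=O)N(Cc2ccc(-n3cncn3)cc2)C2CCCCCC2)c(C)c1` has not been measured; it differs from compound 2 by 1H-1,2,4-triazol-1-yl in place of 5-methyl-1,3,4-oxadiazol-2-yl on an aromatic carbon. Within the data shown here, no step between two measured compounds is available, so the size of the change can only be expected, not read off. Compound 4 is expected to give about 0.5 mg/kg in this assay, within a range from 0.15 mg/kg to 2 mg/kg, and the step that the limit leaves unreadable from compound 2 to compound 4 is estimated to stay near the limit, with no clear direction beyond the scatter.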

Compound 4, dose for half-maximal effect: > 1 mg/kg
Compound 4: a limit, no number; the forecaster's own chance of this, stated with the estimate: 50%; at least 2.0-fold (0.30 log units) between middle value and limit.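

In this assay compound 4 gives only a limit, > 1 mg/kg. Among these compounds, compound 2 also gives only a limit, > 0.32 mg/kg, so no step from compound 2 to compound 4 can be read. The compounds shown leave open whether 1H-1,2,4-triazol-1-yl or 5-methyl-1,3,4-oxadiazol-2-yl gives an effect at smaller amounts.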